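The compounds below may be only part of what the source reports. "The series", "measured", "known", "first", "only" and "open" are said of these compounds alone.

Three compounds have so far been measured in a functional assay on the whole organism with Rattus norvegicus as the target; a lower number here means that less compound is needed, a higher number that more compound is needed for the effect:

compound 1, `C=CCNC(=S)NCCCCn1nc(-c2ccccc2)ccc1=O`, gives 78.6 mg/kg;
compound 2, `N#CNC(=N)NCCCCn1nc(-c2ccccc2)ccc1=O`, gives 59.3 mg/kg;
compound 3, `CC/N=C(\S)NCCCCn1nc(-c2ccccc2)ccc1=O`, gives 19.8 mg/kg.

Compound 3 stands lowest of the three numbers, and both of its steps lie beyond the scatter: a 4.0-fold lower number from compound 1 to compound 3 (0.60 log units; beyond the scatter) and a 3.0-fold lower number from compound 2 to compound 3 (0.48 log units; beyond the scatter). Between the other two, a 1.3-fold lower number from compound 1 to compound 2 (0.12 log units; within the scatter).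

Compound 4, `CN(C)/C(=N/CCCn1nc(-c2ccccc2)ccc1=O)NC#N`, differs from compound 3 in a group of 8 heavy atoms (4 carbon, 4 nitrogen; no ring) in place of a group of 7 heavy atoms (4 carbon, 2 nitrogen, 1 sulfur; no ring), on a saturated chain carbon, three bonds along the chain from an aromatic nitrogen. In effect the thiourea of compound 3 is exchanged for a cyanoguanidine bearing two methyl groups on one nitrogen, and the saturated chain between the aromatic nitrogen and this group is one carbon shorter. Within the data shown here, two measured steps bear on the exchange of the thiourea for a cyanoguanidine: the step from compound 1 to compound 2 went this way and stayed within the scatter, whereas the step from compound 2 to compound 3 went the opposite way and gave a modest drop. Among the measured compounds shown here, no measured step shortens the chain, so that part of the change is without precedent here. On balance a modest rise in this assay is expected, a 2.0-fold higher number from compound 3 to compound 4 (0.31 log units; beyond the scatter), roughly returning toward the level of compound 2. The estimate for compound 4 is therefore 40 mg/kg, with a range from 15 mg/kg to 110 mg/kg.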

Compound 4, dose for half-maximal effect: 93.1 mg/kg
Beside the measured number, compound 4's estimate is 2.3-fold (0.37 log units) below it, and the stated range covers the measured number.
By their numbers in this assay, from the lowest: compound 3; then compounds 2, 1 and 4 (each within the scatter of the next).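

In this assay, the change on a saturated chain carbon, three bonds along the chain from an aromatic nitrogen, gives up what the ethyl thiourea had gained (a 4.7-fold higher number from compound 3 to compound 4 (0.67 log units; beyond the scatter)), and this modest step lies beyond the scatter. Against the other two compounds the new structure shows no separation (a 1.6-fold higher number from compound 2 to compound 4 (0.20 log units; within the scatter); a 1.2-fold higher number from compound 1 to compound 4 (0.07 log units; within the scatter)), so the dimethyl cyanoguanidine on its shorter chain falls together with the plain cyanoguanidine and the allyl thiourea, and among the four only compound 3 stands apart, with steps to all three others printed as beyond the scatter. The step to compound 4 changes the end group and the chain together, so it cannot be divided between them, and nothing measured here gives a reason for the result.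

The compounds shown leave open what the dimethyl cyanoguanidine does on the chain of compound 3, and what the ethyl thiourea does on the shorter chain of compound 4, either of which would separate the two parts of this step. They also leave open whether a longer chain, or a urea or a primary amine in place of the thiourea, would keep the low number of compound 3 or lower it further.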